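This account rests on a few compounds, and the source may have more. Where it says the series, first, only, none or still open, it means among the compounds named here.

In a functional assay on V79 cells (Cricetulus griseus) for cytotoxicity, read by colony formation (on this read-out lower numbers stand for stronger inhibition and higher numbers for weaker inhibition), compound 1 `CNCC1(C)CCN(c2c(F)cc3c(=O)c(C(=O)O)cn(C4CC4)c3c2Cl)C1` gives 23 ug/mL and compound 2 `CNCC1(C)CCN(c2c(F)cc3c(=O)c(C(=O)O)cn(C4CC4)c3c2OC)C1` gives 120 ug/mL, the higher of the two numbers. Compound 3 `COc1c(N2CCCC(N)C2)c(F)cc2c(=O)c(C(=O)O)cn(C3CC3)c12` keeps the methoxy group of compound 2 and differs at one place: 3-aminopiperidin-1-yl in place of 3-methyl-3-((methylamino)methyl)pyrrolidin-1-yl on an aromatic carbon, with 3-aminopiperidin-1-yl in place of 3-methyl-3-((methylamino)methyl)pyrrolidin-1-yl on an aromatic carbon. Going by the values given here, the only measured step, a 5.2-fold higher number from compound 1 to compound 2 (0.72 log units; beyond the scatter), is modest and concerns methoxy in place of chloro, so no measured step covers this change. The estimated step is a 1.6-fold lower number from compound 2 to compound 3 (0.20 log units; within the scatter), expected to stay small and lean toward a lower number in this assay. For compound 3 the expected value is 75 ug/mL, with an estimated range of 25 ug/mL to 220 ug/mL.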

Compound 3, half-maximal inhibitory concentration: 69 ug/mL
The estimate for compound 3 lay 1.1-fold (0.04 log units) above the measured number; measured number inside the range.
By their numbers in this assay, from the lowest: compound 1; then compounds 3 and 2 (each within the scatter of the next).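

With the methoxy group kept, the aromatic carbon ortho to a fluoro group takes 3-aminopiperidin-1-yl in place of 3-methyl-3-((methylamino)methyl)pyrrolidin-1-yl, and this assay shows a 1.7-fold lower number from compound 2 to compound 3 (0.24 log units; within the scatter). The earlier pair covered only methoxy in place of chloro; this step shows that exchanging these two amine rings at this carbon leaves the number within the scatter. Nothing available bears on the cause of this result.

Open, from the compounds shown here alone, is whether the same exchange stays this small with chloro in place of methoxy. Also open, going by these compounds, is how a piperazin-1-yl group or an open-chain amine at this carbon would read.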